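Stripping the Ester Chain from Compound 3

A few compounds are considered here, and "the series" means these few. Any claim that something is new, unique, unknown or untested is made for them only; others in the source may bear on it.

In a functional assay on A549 cells (Homo sapiens) for inhibition, read by MTT assay, with a stated time of 48 h (a lower number here means a stronger inhibitor, a higher number a weaker inhibitor), three esters sharing one core have been measured. Compound 1 `COc1ccc(N(C)c2nc(C)nc3ccccc23)cc1C(=O)OCC[Se]C#N` gives 353 nM, compound 2 `COc1ccc(N(C)c2nc(C)nc3ccccc23)cc1C(=O)OCCC[Se]C#N` gives 250 nM, and compound 3 `COc1ccc(N(C)c2nc(C)nc3ccccc23)cc1C(=O)OCCCC[Se]C#N` gives 155 nM. Compound 3 holds the lowest number of the three, but only a 2.3-fold lower number from compound 1 to compound 3 (0.36 log units; beyond the scatter) passes beyond the scatter, while a 1.6-fold lower number from compound 2 to compound 3 (0.21 log units; within the scatter) and a 1.4-fold lower number from compound 1 to compound 2 (0.15 log units; within the scatter) do not.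

Compound 4 `COc1ccc(N(C)c2nc(C)nc3ccccc23)cc1` differs from compound 3 by one change: a hydrogen atom in place of a group of 10 heavy atoms (6 carbon, 1 nitrogen, 2 oxygen, 1 selenium; no ring), on an aromatic carbon. The change falls on an aromatic carbon, ortho to a methoxy group.

The measured steps bear on this only loosely. Among the compounds with values here, they vary the chain length alone, and none removes the ester, so the data hold no step of this kind. The whole span of the series is a 2.3-fold lower number from compound 1 to compound 3 (0.36 log units; beyond the scatter), so the activity is not expected to hang on the chain, and the core alone is expected to keep it. This is a judgement rather than a reading of the data, and it points towards a lower number with a wide margin. The expected size of the change in this assay is a 3.9-fold lower number from compound 3 to compound 4 (0.59 log units; beyond the scatter), which would lie beyond the scatter. For compound 4 the estimate is 40 nM, with an expected range from 4 nM to 400 nM.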

Compound 4, half-maximal inhibitory concentration: 3 nM
The estimate for compound 4 lay 13-fold (1.12 log units) above the measured number, and the stated range ends above it.
By their numbers in this assay, from the lowest: compound 4; then compounds 3, 2 and 1 (each within the scatter of the next, the first and the last beyond it).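

The hydrogen atom at this aromatic carbon, ortho to a methoxy group, shows that activity in this assay does not depend on the ester chain, since the core without it gives a far lower number than any of the three esters: there is a 52-fold lower number from compound 3 to compound 4 (1.71 log units; beyond the scatter), an 83-fold lower number from compound 2 to compound 4 (1.92 log units; beyond the scatter) and a 120-fold lower number from compound 1 to compound 4 (2.07 log units; beyond the scatter). Changing the chain length had shown only a narrow span (a 2.3-fold lower number from compound 1 to compound 3 (0.36 log units; beyond the scatter)), whereas removing the chain altogether moves the number much further, so that all three esters lie well on the weaker side of compound 4. No measured evidence shown here bears on the reason for this large step.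

The compounds shown remove the ester, the chain, the selenium and the nitrile together, so they leave open which of these parts accounts for the higher numbers of the esters. They also leave open how a small group at this carbon, such as a carboxylic acid, a methyl ester or a fluorine atom, would stand against the hydrogen atom of compound 4 and against the longer chains.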